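The compounds below may be only part of what the source reports. "The series", "measured", "known", "first", "only" and "open" are said of these compounds alone.

Compound 1 `CCn1c(CNc2ccccc2)nnc1SCC(=O)Nc1ccc(OC)cc1` is assessed in an assay on isolated protein for inhibition of long-chain fatty acid transport protein 1 (Mus musculus); a higher number here means a weaker inhibitor, a lower number a stronger inhibitor. In this assay compound 1 gives only a limit, > 10000 nM. Compound 3 `CCn1c(CNc2ccccc2)nnc1SCc1nc2cc(C)ccc2o1` likewise returns only a limit in this assay, > 10000 nM. Compound 2 `CCC(=O)c1ccc2oc(CS(=O)(=O)c3nnc(CNc4ccccc4)n3CC)nc2c1` gives a number in this assay, 11900 nM, and so the whole set reads as weak inhibition. Compound 1 thus stands with the bulk of what is shown, since the limit of > 10000 nM in this assay, at which 2 of the 3 values shown sit, holds two of the three values. Compound 4 `CCn1c(CNc2ccccc2)nnc1SCC(=O)Nc1ccccc1` carries the change (hydrogen in place of methoxy on an aromatic carbon). Going by the values given here, no measured step between compounds differing in one place is available, so no direction can be drawn from the data. A step that the limit leaves unreadable from compound 1 to compound 4 is expected, within the scatter, most likely again only a limit. Compound 4 is therefore estimated at 15000 nM, with a range from 5000 nM to 50000 nM.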

Compound 4, half-maximal inhibitory concentration: > 10000 nM
Compound 4 gave a limit, no number; the forecaster's own chance of this, stated with the estimate: 75%; the middle value does not contradict the limit.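

Compound 1 and compound 4 each give only a limit, so no step can be read for hydrogen in place of methoxy. The compounds shown leave open whether this change alters inhibition at all, as most values rest on a single limit: the limit of > 10000 nM in this assay, at which 3 of the 4 values shown sit.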